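This account rests on a few compounds, and the source may have more. Where it says the series, first, only, none or still open, it means among the compounds named here.

Measured compounds in a functional assay on PC-3 cells (Homo sapiens) for cytotoxicity, read by MTT assay, with a stated time of 72 h; a lower number here means a stronger inhibitor, a higher number a weaker inhibitor:
compound 1 `O=C(Nc1ccc(Oc2ccnc3[nH]ccc23)cc1)c1nccc(-c2cccc(Cl)c2)n1` – 7800 nM
compound 2 `COc1ccc(-c2ccnc(C(=O)Nc3ccc(Oc4ccnc5[nH]ccc45)cc3)n2)cc1` – 17300 nM
compound 3 `O=C(Nc1ccc(Oc2ccnc3[nH]ccc23)cc1)c1nccc(-c2ccc(F)cc2)n1` – reported as "not active" (no number reported), with no number

Compound 1 holds the lowest of the two numbers; its nearest neighbour is compound 2, with a 2.2-fold higher number from compound 1 to compound 2 (0.35 log units; beyond the scatter). Compound 3 gives no number at all.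

Compound 4 `O=C(Nc1ccc(Oc2ccnc3[nH]ccc23)c(F)c1)c1nccc(-c2cccc(Cl)c2)n1` differs from compound 1 by fluoro in place of hydrogen on an aromatic carbon; the change sits on the central ring, ortho to a large group and meta to a large group. For the measured compounds named here, the one measured step, a 2.2-fold higher number from compound 1 to compound 2 (0.35 log units; beyond the scatter), concerns a substituent elsewhere and does not bear on this change; no measured pair shows a fluoro entering at this place. With nothing to point either way, the expectation for compound 4 is a step within the scatter, a 1.0-fold lower number from compound 1 to compound 4 (0.02 log units; within the scatter). Compound 4 is therefore estimated at 7500 nM, with a range of 3000 nM to 19000 nM.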

Compound 4, half-maximal inhibitory concentration: 1380 nM
For compound 4 the middle estimate is 5.4-fold (0.74 log units) above the measured one; measured number outside the range, below it.
By their numbers in this assay, from the lowest: compound 4; then compound 1; then compound 2.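

In this assay, fluoro in place of hydrogen on an aromatic carbon, ortho to a large group and meta to a large group, gives a 5.7-fold lower number from compound 1 to compound 4 (0.75 log units; beyond the scatter). This shows that the number responds to a single added fluorine on this ring, whereas the earlier step concerned only a substituent elsewhere. Nothing available gives a reason for this step.

On these data alone, whether a chloro, a methyl or an amine at this place would give a similar step remains open. So does whether fluoro here gives the same step alongside the 4-methoxyphenyl of compound 2.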